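The source may hold more compounds than are shown below. What is called first, only, known or untested is meant among the compounds shown, and "the series" means these compounds.

Measured compounds in a functional assay on HCT-116 cells (Homo sapiens) for cytotoxicity, read by MTT assay, with a stated time of 48 h; on this read-out lower numbers stand for stronger inhibition and higher numbers for weaker inhibition:
compound 1 `O=C(/C=C/c1ccc2c(c1)B(O)OC2)c1ccccc1` gives 6100 nM
compound 2 `O=C(/C=C/c1ccc2c(c1)B(O)OC2)c1cccnc1` gives 20500 nM
compound 3 `O=C(/C=C/c1ccc2c(c1)B(O)OC2)c1ccc(F)cc1` gives 2800 nM

Compound 3 holds the lowest number of the three; its nearest neighbour is compound 1, a 2.2-fold lower number from compound 1 to compound 3 (0.34 log units; beyond the scatter), and its furthest is compound 2, a 7.3-fold lower number from compound 2 to compound 3 (0.86 log units; beyond the scatter). Compound 4 `Cc1cccc(C(=O)/C=C/c2ccc3c(c2)B(O)OC3)c1` has not been measured in this assay. Relative to compound 3 the change is 3-methylphenyl in place of 4-fluorophenyl on a carbonyl carbon.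

Among the compounds with values here, no measured step exchanges one group for another on the same six-membered aromatic ring of carbon only; the nearest comparisons are a 2.2-fold lower number from compound 1 to compound 3 (0.34 log units; beyond the scatter) and a 3.4-fold higher number from compound 1 to compound 2 (0.53 log units; beyond the scatter), both modest. Compound 4, like compound 1 and compound 3, carries a six-membered aromatic ring of carbon only on the carbonyl carbon, so its number is expected to sit between those two, most likely nearer compound 1. The step of a 1.6-fold higher number from compound 3 to compound 4 (0.21 log units; within the scatter) is therefore expected to be modest and upward, possibly within the scatter. Compound 4 is estimated at 4500 nM, with a range of 1800 nM to 11000 nM.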

Compound 4, half-maximal inhibitory concentration: 6700 nM
Compound 4: the middle estimate sits 1.5-fold (0.17 log units) below what was measured; low and high end bracket the measured number.
By their numbers in this assay, from the lowest: compound 3; then compounds 1 and 4 (each within the scatter of the next); then compound 2.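

In this assay, putting a methyl on the phenyl at the carbonyl carbon, as 3-methylphenyl, gives no readable change (a 1.1-fold higher number from compound 1 to compound 4 (0.04 log units; within the scatter)). The lower number seen with 4-fluorophenyl therefore does not extend to every substituted phenyl at this place (a 2.4-fold higher number from compound 3 to compound 4 (0.38 log units; beyond the scatter)), while 3-methylphenyl stays clear of pyridin-3-yl (a 3.1-fold lower number from compound 2 to compound 4 (0.49 log units; beyond the scatter)). No measurement is at hand that accounts for these differences.

The compounds shown leave open whether the identity of the group or its place on the ring separates compound 3 from compound 4, as the two differ in both. Also open, going by these compounds, is how a methoxy group, an amine or a carboxylic acid on this ring would read in this assay.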